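The compounds below may be only part of what the source reports. "The series", "measured", "known", "first", "only" and "open" are said of these compounds alone.

Compound 1 `CN(C)CCCn1nc(C2=C(c3cn(C)c4ccccc34)C(=O)NC2=O)c2cccnc21` carries a dimethylamino terminus on the propyl chain and a free amide nitrogen in the core. In a functional assay on SMMC-7721 cells (Homo sapiens) for antiproliferative activity, read by MTT assay, with a stated time of 48 h (on this read-out higher numbers stand for weaker inhibition and lower numbers for stronger inhibition), compound 1 gives only a limit, > 100000 nM, and no number. Compound 2 `CN(C)CCCn1nc(C2=C(c3cn(C)c4ccccc34)C(=O)N(c3ccccc3)C2=O)c2cccnc21` gives 31200 nM in this assay, so the step of an at least 3.2-fold lower number from compound 1 to compound 2 (0.50 log units; beyond the scatter) is an at least modest drop. Compound 3 `Cn1cc(C2=C(c3nn(CCCCn4ccnc4)c4ncccc34)C(=O)N(c3ccccc3)C2=O)c2ccccc21` gives 1760 nM in this assay; the step of an 18-fold lower number from compound 2 to compound 3 (1.25 log units; beyond the scatter) is large and concerns the chain terminus, as does the step to compound 4. Compound 4 `Cn1cc(C2=C(c3nn(CCCN4CCCCC4)c4ncccc34)C(=O)NC2=O)c2ccccc21` differs from compound 1 by piperidin-1-yl in place of dimethylamino on a saturated chain carbon, three bonds along the chain from an aromatic nitrogen. Because compound 1 sits at the limit of > 100000 nM in this assay, at which 1 of the 3 values shown sits, the amide-free parent is weak; the terminus change in an 18-fold lower number from compound 2 to compound 3 (1.25 log units; beyond the scatter) suggests a moderate drop is expected. Compound 4 is therefore expected at 50000 nM (range 15000 nM to 200000 nM), an expected step of an at least 2.0-fold lower number from compound 1 to compound 4 (0.30 log units; that floor lies within the scatter).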

Compound 4, half-maximal inhibitory concentration: 7670 nM
Compound 4: the middle estimate sits 6.5-fold (0.81 log units) above what was measured; the measured number lies below the stated range.
By their numbers in this assay, from the lowest: compound 3; then compound 4; then compound 2. At a limit, above all of these: compound 1.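

On the core that keeps the amide hydrogen, exchanging the chain terminus alone gives an at least 13-fold lower number from compound 1 to compound 4 (1.11 log units; beyond the scatter) in this assay. The earlier terminus change stood only on the core with phenyl on the amide nitrogen, so a terminus effect now appears on both cores. Compound 1 gives a limit and no number, so the size of this step is only a floor: the limit of > 100000 nM in this assay, at which 1 of the 4 values shown sits.

Open, from the compounds shown here alone, is whether a morpholin-4-yl or pyrrolidin-1-yl terminus would behave like piperidin-1-yl. Also open, going by these compounds, is how piperidin-1-yl behaves with phenyl on the amide nitrogen or on a longer chain.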